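This account rests on a few compounds, and the source may have more. Where it says the series, first, only, none or still open, it means among the compounds named here.

Working notes on the series. In an assay on HEK293 cells for inhibition of potassium channel subfamily T member 1 (Homo sapiens), read by thallium flux (on this read-out lower numbers stand for stronger inhibition and higher numbers for weaker inhibition), compound 1 `COc1ccc(C(F)(F)F)cc1NC(=O)CN1CCN(S(=O)(=O)N2CCC(C)CC2)CC1` gives 2400 nM, compound 3 `COc1ccc(Cl)cc1NC(=O)[C@H](C)N1CCN(S(=O)(=O)N2CCC(C(F)(F)F)CC2)CC1` gives 3400 nM, and compound 2 `COc1ccc(Cl)cc1NC(=O)CN1CCN(S(=O)(=O)N2CCC(C)CC2)C[C@@H]1C` gives 3500 nM; the number for compound 2 lies within the scatter of both the number for compound 3 and the number for compound 1, so no ranking among the three is supported. Compound 4 `COc1ccc(Cl)cc1NC(=O)CN1CCN(S(=O)(=O)N2CCC(C)CC2)C[C@H]1C` is related to compound 2 as follows: the two compounds have the same atoms and bonds and differ only in configuration as drawn: 1 of 1 stereo elements differ; a stereocentre at a saturated ring carbon is drawn S in compound 2 and R in compound 4. Within the data shown here, no measured pair isolates a change of configuration alone, so there is no precedent to size the step. With nothing beyond the scatter expected, the step from compound 2 to compound 4 in this assay is estimated as no change at the digits printed from compound 2 to compound 4 (within the scatter). For compound 4 the value in this assay is expected near 3500 nM, within 1400 nM to 9000 nM.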

Compound 4, half-maximal inhibitory concentration: 2400 nM
Compound 4: middle estimate off by 1.5-fold (0.16 log units), on the high side; the measured number falls inside the stated range.
By their numbers in this assay, from the lowest: compounds 1, 4, 3 and 2 (each within the scatter of the next).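

This pair gives the series its first step at a single place: in this assay, the change of configuration at the saturated ring carbon, from S to R, gives a 1.5-fold lower number from compound 2 to compound 4 (0.16 log units; within the scatter). At this position, then, the drawn configuration gives no separation beyond the scatter. The comparison involves no other structural change: the fact that compounds 2 and 4 differ only in the configuration as drawn

Still open, from the compounds shown here alone, is how an unsubstituted ring carbon, or an ethyl or hydroxymethyl group there, would compare with compound 2 and compound 4. Also open, going by these compounds, is whether the same change of configuration stays within the scatter when the other groups differ.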